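A few compounds are considered here, and "the series" means these few. Any claim that something is new, unique, unknown or untested is made for them only; others in the source may bear on it.

Working notes on a series built on one shared core, varied at the aryl group on the carbon with a double bond to nitrogen. Compound 1 `S=C(Nc1ccccc1)N1N=C(c2ccccc2)CC1c1ccc2c(c1)OCCO2` carries a plain phenyl there; in a functional assay on HCT-116 cells (Homo sapiens) for antiproliferative activity, read by MTT assay, with a stated time of 48 h (on this read-out higher numbers stand for weaker inhibition of growth and lower numbers for stronger inhibition of growth), compound 1 gives 57600 nM. Compound 2 `S=C(Nc1ccccc1)N1N=C(c2ccc(Br)cc2)CC1c1ccc2c(c1)OCCO2` adds bromo on an aromatic carbon, and in this assay compound 2 gives 32100 nM; the step of a 1.8-fold lower number from compound 1 to compound 2 (0.25 log units; within the scatter) lies within the scatter. Compound 3 `O=[N+]([O-])c1ccc(C2=NN(C(=S)Nc3ccccc3)C(c3ccc4c(c3)OCCO4)C2)cc1` carries nitro instead. In this assay compound 3 reaches only > 200000 nM, which is a limit of the assay and not a number, the line (the limit of > 200000 nM in this assay, at which 1 of the 3 values shown sits). Compound 3 thus stands at the weak end of the three values shown, since the steps of an at least 3.4-fold higher number from compound 1 to compound 3 (0.54 log units; beyond the scatter) and an at least 6.2-fold higher number from compound 2 to compound 3 (0.79 log units; beyond the scatter) are both beyond the scatter.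

Compound 4 `S=C(Nc1ccccc1)N1N=C(c2cccs2)CC1c1ccc2c(c1)OCCO2` differs from compound 3 by thiophen-2-yl in place of 4-nitrophenyl on a carbon with a double bond to nitrogen. Within the data shown here, the steps that bear on this change are an at least 3.4-fold higher number from compound 1 to compound 3 (0.54 log units; beyond the scatter) and an at least 6.2-fold higher number from compound 2 to compound 3 (0.79 log units; beyond the scatter), both at least modest; compound 4 removes the nitro group that marked both of them and carries a five-membered aromatic ring instead of a six-membered one. The step expected in this assay is therefore an at least 4.0-fold lower number from compound 3 to compound 4 (0.60 log units; beyond the scatter), back toward the numbers of compound 1 and compound 2. The estimate for compound 4 in this assay is 50000 nM, with a range from 20000 nM to 150000 nM.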

Compound 4, concentration for 50% growth inhibition: 8190 nM
Compound 4: middle estimate off by 6.1-fold (0.79 log units), on the high side; measured number below the stated range.
By their numbers in this assay, from the lowest: compound 4; then compounds 2 and 1 (each within the scatter of the next). At a limit, above all of these: compound 3.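

Among these compounds, the earlier compounds showed only one step within the scatter and one loss at the aryl position on the carbon with a double bond to nitrogen; in this assay, thiophen-2-yl gives the first gains beyond the scatter, with a 7.0-fold lower number from compound 1 to compound 4 (0.85 log units; beyond the scatter) and a 3.9-fold lower number from compound 2 to compound 4 (0.59 log units; beyond the scatter). The aromatic ring itself at this position can therefore move the number, not only a substituent on a six-membered aromatic ring of carbon only, and compound 4 has the lowest number of the four. The step of an at least 24-fold lower number from compound 3 to compound 4 (1.38 log units; beyond the scatter) gives only a bound and not a size, as the value of compound 3 is a limit of the assay and not a number: the limit of > 200000 nM in this assay, at which 1 of the 4 values shown sits.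

The compounds shown leave open whether the step follows the smaller ring or its sulfur atom, since thiophen-2-yl is the only five-membered ring here; a furan or a pyridine at this position would help separate the two. Also open, going by these compounds, is how a methyl or chloro group on the thiophene ring would change the number.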